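Inverting One Stereocentre in a Trimethyl Ring Analogue

A few compounds are considered here, and "the series" means these few. Any claim that something is new, unique, unknown or untested is made for them only; others in the source may bear on it.

Compound 1: `COc1cc2c(cc1N1C[C@@H](C)N[C@@H](C)C1)N(S(=O)(=O)c1ccc(-c3ccccn3)s1)CC2`; in a functional assay for agonist activity at growth hormone secretagogue receptor type 1 (Homo sapiens), read by FLIPR (on this read-out higher numbers stand for an effect only at larger amounts of compound and lower numbers for an effect already at smaller amounts), compound 1 gives 0.159 nM.
Compound 2: `COc1cc2c(cc1N1C[C@H](C)NC(C)(C)C1)N(S(=O)(=O)c1ccc(-c3ccccn3)s1)CC2`; in this assay compound 2 gives 0.794 nM.

Among the compounds with values here, compound 2 gives the higher of the two numbers measured so far; its only neighbour is compound 1, and the step of a 5.0-fold higher number from compound 1 to compound 2 (0.70 log units; beyond the scatter) is the sole comparison available. Compound 3, `COc1cc2c(cc1N1C[C@@H](C)NC(C)(C)C1)N(S(=O)(=O)c1ccc(-c3ccccn3)s1)CC2`, shares every atom and bond with compound 2; the difference is the two compounds have the same atoms and bonds and differ only in configuration as drawn: 1 of 1 stereo elements differ; a stereocentre at a saturated ring carbon is drawn S in compound 2 and R in compound 3. Within the data shown here, no measured pair in this set differs only in configuration at a saturated ring carbon, so the one measured step, which exchanges whole ring groups, does not bear on this change. Among the measured compounds shown here, an inversion of a single stereocentre has no comparable precedent here, and the expectation for this assay therefore rests on compound 2 alone, with a wide range. The step from compound 2 to compound 3 is expected to be a 1.9-fold higher number from compound 2 to compound 3 (0.28 log units; within the scatter). Compound 3 is thus estimated at 1.5 nM, with a range from 0.2 nM to 12 nM.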

Compound 3, half-maximal effective concentration: 10 nM
The estimate for compound 3 lay 6.7-fold (0.82 log units) below the measured number, and the stated range covers the measured number.
By their numbers in this assay, from the lowest: compound 1; then compound 2; then compound 3.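

In this assay, the configuration at this saturated ring carbon matters on its own, with a 13-fold higher number from compound 2 to compound 3 (1.10 log units; beyond the scatter). Nothing else separates the two compounds, so the gap belongs to this stereocentre, drawn S in compound 2 and R in compound 3: the fact that compounds 2 and 3 differ only in the configuration as drawn. Exchanging the ring group of compound 1 therefore has no single outcome: with the R configuration it gives a 63-fold higher number from compound 1 to compound 3 (1.80 log units; beyond the scatter), a large step where the S configuration gave only a modest one.

The compounds shown do not tell whether the same preference for the S configuration would hold with an ethyl group in place of the methyl on this ring carbon. They also leave open whether it would persist with the ring's gem-dimethyl carbon replaced by a plain methylene.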